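Moving the Pyridine Nitrogen on a Shared Core

This account rests on a few compounds, and the source may have more. Where it says the series, first, only, none or still open, it means among the compounds named here.

Measured in an assay on isolated protein for inhibition of Retinaldehyde dehydrogenase 3 (Homo sapiens); a lower number here means a stronger inhibitor, a higher number a weaker inhibitor:
Compound 1 `Cn1ncc2c(=O)n(-c3ccccc3)c(COc3cccc(F)c3)nc21`: 780 nM
Compound 2 `Cn1ccc2c(=O)n(-c3ccccc3)c(SCc3cccc(F)c3)nc21`: 600 nM
Compound 3 `CC(Sc1nc2nn(C3COC3)cc2c(=O)n1-c1ccccc1)c1ccccn1`: 480 nM

All three compounds share a core and differ in the ring fused to it, in the linker, and in the group at the chain end. Compound 3 gives the lowest of the three numbers, yet its gaps to compound 2 and to compound 1 both lie within the scatter, so no order among them can be read. Compound 4 `CC(Sc1nc2nn(C3COC3)cc2c(=O)n1-c1ccccc1)c1cccnc1` differs from compound 3 in one place: pyridin-3-yl in place of pyridin-2-yl on a saturated chain carbon bound to a saturated chain carbon and a sulfur. For the measured compounds named here, no pair of measured compounds isolates this change, so its effect in this assay is unknown and a step within the scatter, in no set direction, is expected. Compound 4 is expected to give 650 nM, between 250 nM and 2000 nM, an estimated step of a 1.4-fold higher number from compound 3 to compound 4 (0.13 log units; within the scatter).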

Compound 4, half-maximal inhibitory concentration: 250 nM
Compound 4: middle estimate off by 2.6-fold (0.41 log units), on the high side; the range from low to high includes it.
By their numbers in this assay, from the lowest: compounds 4, 3, 2 and 1 (each within the scatter of the next, the first and the last beyond it).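

For the compounds shown here, compound 3 and compound 4 form the first pair that isolates pyridin-3-yl in place of pyridin-2-yl at this saturated chain carbon. In this assay this swap gives a 1.9-fold lower number from compound 3 to compound 4 (0.28 log units; within the scatter) and so no direction can be read: on this one pair, where the nitrogen sits in the pyridine ring has no effect that stands clear of the scatter. Still open, as far as these compounds go, is whether pyridin-4-yl or an amine at this place would behave alike, and whether the same swap would hold on a different linker. Nothing measured here offers an explanation for this result.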